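The compounds below may be only part of what the source reports. "The series", "measured", "known", "first", "only" and "open" are said of these compounds alone.

Measured compounds:
Compound 1 `Cc1nc(C(F)(F)F)ncc1C(=O)Nc1cc(C(F)(F)F)cc(C(F)(F)F)c1` gives > 10000 nM in an assay on Jurkat cells for activation of nuclear factor NF-kappa-B complex (Homo sapiens) (on this read-out higher numbers stand for weaker inhibition and lower numbers for stronger inhibition), a limit of the assay.
Compound 2 `Cc1cc(C(=O)Nc2cc(C(F)(F)F)cc(C(F)(F)F)c2)nc(Cl)n1` gives > 10000 nM in this assay, also a limit.
Compound 3 `O=C(Nc1cc(C(F)(F)F)cc(C(F)(F)F)c1)c1cnc(C(F)(F)F)nc1C(F)(F)F` gives > 10000 nM in this assay, again a limit.

The change from compound 1 to compound 3 is trifluoromethyl in place of methyl on an aromatic carbon, and its step is a step that the two limits leave unreadable from compound 1 to compound 3, since (the limit of > 10000 nM in this assay, at which 3 of the 3 values shown sit). The difference between the cores of compound 1 and compound 2 is not broken down here. Compound 4 `O=C(Nc1cc(C(F)(F)F)cc(C(F)(F)F)c1)c1cc(C(F)(F)F)nc(Cl)n1` arises from compound 2 by the same kind of change, (trifluoromethyl in place of methyl on an aromatic carbon), though here the carbon is meta to a chloro group and meta to a large group rather than ortho to a large group and meta to a trifluoromethyl group. With the earlier step unreadable and (the limit of > 10000 nM in this assay, at which 3 of the 3 values shown sit), the step from compound 2 to compound 4 is expected to be a step that the limit leaves unreadable from compound 2 to compound 4. Compound 4 is therefore estimated at 20000 nM in this assay, most likely again reported only as a limit.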

Compound 4, half-maximal inhibitory concentration: > 10000 nM
Compound 4: no number, only a limit; the forecaster's own chance of this, stated with the estimate: 85%; the middle value lies beyond the limit too.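

No step can be read from compound 2 to compound 4, since both are reported only as limits in this assay: the limit of > 10000 nM in this assay, at which 4 of the 4 values shown sit.

The compounds shown leave open whether trifluoromethyl in place of methyl changes inhibition at all.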